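The source may hold more compounds than are shown below. What is called first, only, known or untested is meant among the compounds shown, and "the series" means these compounds.

Working notes on the series. Compound 1 `CCCCCCCCc1ccc(OCC(=O)Cn2nnnc2-c2cccc(Cl)c2)cc1` and compound 2 `CCCCCCCCc1ccc(OCC(=O)Cn2nnnc2-c2ccncc2)cc1` share the same core and differ only in the aromatic group on it. In an assay on microsomes from brain for inhibition of Fatty-acid amide hydrolase 1 (Rattus norvegicus), read by fluorescence and HPLC, with a stated time of 60 min (on this read-out higher numbers stand for weaker inhibition and lower numbers for stronger inhibition), compound 1 gives 360 nM; in this assay compound 2 gives 190 nM. The step of a 1.9-fold lower number from compound 1 to compound 2 (0.28 log units; within the scatter) shows that swapping 3-chlorophenyl for pyridin-4-yl leaves the two compounds within the scatter of each other, so no order between them can be read from these numbers.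

Compound 3 `CCCCCCCCc1ccc(OCC(=O)Cn2nnnc2-c2cccs2)cc1` is not yet measured. Its change from compound 2 is thiophen-2-yl in place of pyridin-4-yl on an aromatic carbon. Among the compounds with values here, the only step that bears on it is a 1.9-fold lower number from compound 1 to compound 2 (0.28 log units; within the scatter), an exchange of the same aromatic group at the same place, and it stayed within the scatter. No step beyond the scatter is therefore expected in this assay for compound 3. The estimated step is a 1.3-fold higher number from compound 2 to compound 3 (0.12 log units; within the scatter). Compound 3 is expected to give about 250 nM, with a range from 100 nM to 700 nM.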

Compound 3, half-maximal inhibitory concentration: 55 nM
Estimate against measurement, compound 3: 4.5-fold (0.66 log units) above; the whole stated range lies above it.
By their numbers in this assay, from the lowest: compound 3; then compounds 2 and 1 (each within the scatter of the next).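

In this assay, the aromatic group at this place on the core can move the number after all: a 3.5-fold lower number from compound 2 to compound 3 (0.54 log units; beyond the scatter) and a 6.5-fold lower number from compound 1 to compound 3 (0.82 log units; beyond the scatter) both lie beyond the scatter, whereas the exchange between the two six-membered groups stayed within it. Among the three compounds, thiophen-2-yl, a five-membered aromatic ring with sulfur as its hetero atom, stands apart from both pyridin-4-yl and 3-chlorophenyl, so the exchange of one aromatic group for another does not have a uniformly small effect here. Nothing available explains this difference.

Open, on these data alone, is whether the lower number goes with the sulfur, with the five-membered ring or with the attachment point, a question that furan-2-yl and thiophen-3-yl at this place would address. Also open, as far as these compounds go, is whether the step from thiophen-2-yl holds with a chain shorter than the octyl chain on the shared core.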